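Swapping the chlorine pattern on a dihydrofolate reductase inhibitor

The source may hold more compounds than are shown below. What is called first, only, known or untested is meant among the compounds shown, and "the series" means these compounds.

Going by the values given here, compound 1 `NC1=NC2(CCOCC2)N(OCCCOc2ccc(Cl)c(Cl)c2)C(N)=N1` is the only compound here with a number. In an assay on isolated protein for inhibition of Dihydrofolate reductase (Homo sapiens), read by spectrophotometry, using NADPH, with stated times of 5 s and 6 min (a lower number here means a stronger inhibitor, a higher number a weaker inhibitor), compound 1 gives 8.23 nM, a potent result. Compound 2 `NC1=NC2(CCSCC2)N(OCCCOc2cccc(Cl)c2Cl)C(N)=N1` carries a differently arranged dichlorophenyl ring and a sulfur in place of an oxygen in its saturated ring; in this assay compound 2 gives "not determined" (no result reported), so it offers no comparison. Compound 3 `NC1=NC2(CCOCC2)N(OCCCOc2ccc(Cl)cc2Cl)C(N)=N1` keeps everything of compound 1 except the dichlorophenyl ring, which changes as follows: 2,4-dichlorophenyl in place of 3,4-dichlorophenyl on an oxygen on a saturated carbon. Among the compounds with values here, since no measured pair here shows what moving one chlorine does, the size of this step can only be guessed. Two chlorines stay on the ring and the rest of the molecule is unchanged, so a modest loss of potency, near or just beyond the usual scatter, seems the most likely outcome, as the expected step of a 1.8-fold higher number from compound 1 to compound 3 (0.26 log units; within the scatter) expresses. Compound 3 is therefore estimated at 15 nM, with a likely range from 4 nM to 60 nM.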

Compound 3, half-maximal inhibitory concentration: 7.46 nM
The estimate for compound 3 lay 2.0-fold (0.30 log units) above the measured number; the measured number falls inside the stated range.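

In this assay, going by these compounds alone, the swap to 2,4-dichlorophenyl in place of 3,4-dichlorophenyl gives a 1.1-fold lower number from compound 1 to compound 3 (0.04 log units; within the scatter), the first measured pair in this set. Moving one chlorine around the ring therefore makes no difference that can be told from assay scatter, so for these two patterns the dichlorophenyl ring need not keep one exact arrangement of chlorines for the compound to remain a potent inhibitor. Nothing given here bears on why the two patterns match.

Still open, as far as these compounds go, is whether a ring with a single chlorine, a trifluoromethyl group in place of the chlorines, or a longer chain between the ring and the shared core would hold potency as well. Compound 2, with sulfur in its saturated ring, has no reported result in this assay, so what that sulfur does cannot be read.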